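Chloro for bromo at the para position of compound 1

The source may hold more compounds than are shown below. What is called first, only, known or untested is meant among the compounds shown, and "the series" means these compounds.

Working notes on a functional assay on K562 cells (Homo sapiens) for antiproliferative activity, read by MTT assay, with a stated time of 24 h; on this read-out higher numbers stand for weaker inhibition and lower numbers for stronger inhibition. Compound 1 `COc1ccc(C(=O)/C=C/c2ccc(Br)cc2)c2c1C=CC(C)(C)O2` gives only a limit in this assay, > 10000 nM. Compound 2 `COc1ccc(C(=O)/C=C/c2ccc3ccccc3c2)c2c1C=CC(C)(C)O2` gives 3670 nM in this assay. Compound 3 `COc1ccc(C(=O)/C=C/c2cccc3ccccc23)c2c1C=CC(C)(C)O2` likewise gives only a limit, > 10000 nM. Among the three values shown, compound 1 stands at the limit of > 10000 nM in this assay, at which 2 of the 3 values shown sit, so its place relative to compound 2 cannot be expressed as a number; the values of compound 1 and compound 3 are both limits and not numbers. Among the compounds with values here, no two measured compounds differ in a single place, and so no measured step exists in this set.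

Compound 4 `COc1ccc(C(=O)/C=C/c2ccc(Cl)cc2)c2c1C=CC(C)(C)O2` is the unmeasured member. Its difference from compound 1 is chloro in place of bromo on an aromatic carbon. Within the data shown here, no measured pair isolates a swap of bromo for chloro, so the expectation rests on the limit of compound 1 alone. In this assay the step from compound 1 to compound 4 is expected to be small, within the scatter and in no particular direction; the estimated step is a step that the limit leaves unreadable from compound 1 to compound 4. Compound 4 is therefore expected to give 15000 nM in this assay, with a range from 5000 nM to 50000 nM. A further limit rather than a number is likely because compound 1 sits at the limit of > 10000 nM in this assay, at which 2 of the 3 values shown sit.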

Compound 4, half-maximal inhibitory concentration: > 10000 nM
Compound 4: only a limit was reported (the forecaster's own chance of this, stated with the estimate: 70%); the middle value lies beyond the limit too.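

In this assay compound 4 gives > 10000 nM as a limit and not a number. Compound 1 also stands at a limit, so no step can be read for the change of bromo to chloro between compound 1 and compound 4: the limit of > 10000 nM in this assay, at which 3 of the 4 values shown sit. The compounds shown leave open whether 4-bromophenyl and 4-chlorophenyl differ at all in this assay on this core.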